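The source may report more compounds than this note shows. Statements on the series, on what has been measured and on what is new or still open speak of the compounds shown alone.

Measured compounds:
Compound 1 `CCCCOc1c(-c2cc(OC)c(OC)c(OC)c2)oc2ccccc2c1=O` — in a functional assay on DU-145 cells (Homo sapiens) for antiproliferative activity, read by WST assay, with a stated time of 3 days (a higher number here means a weaker inhibitor, a lower number a stronger inhibitor), compound 1 gives > 50000 nM, which is a limit of the assay.
Compound 2 `CCCCCOc1c(-c2cc(OC)c(OC)c(OC)c2)oc2ccccc2c1=O` — in this assay compound 2 gives > 50000 nM, again only a limit.
Compound 3 `CCCN(CCC)CCCOc1c(-c2cc(OC)c(OC)c(OC)c2)oc2ccccc2c1=O` — in this assay compound 3 gives > 50000 nM, also a limit.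

Compound 2 thus stands at the limit, as do the other two values shown; see (the limit of > 50000 nM in this assay, at which 3 of the 3 values shown sit). The steps a step that the two limits leave unreadable from compound 1 to compound 2, a step that the two limits leave unreadable from compound 1 to compound 3 and a step that the two limits leave unreadable from compound 2 to compound 3 cannot be read, since both ends sit at the limit.

Compound 4 `CCCCN(CCCC)CCCCCOc1c(-c2cc(OC)c(OC)c(OC)c2)oc2ccccc2c1=O` differs from compound 2 by dibutylamino in place of hydrogen on a saturated chain carbon, five bonds along the chain from an oxygen on an aromatic ring. Among the measured compounds shown here, the only step bearing on a chain amine, from compound 2 to compound 3, is unreadable, so no direction can be taken from it. Compound 4 is expected to remain at the limit, with a step that the limit leaves unreadable from compound 2 to compound 4 from compound 2. The estimate for compound 4 in this assay is 60000 nM, between 15000 nM and 200000 nM.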

Compound 4, half-maximal inhibitory concentration: > 50000 nM
Compound 4 gave a limit, no number; the forecaster's own chance of this, stated with the estimate: 80%; the middle value lies beyond the limit too.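

In this assay, among the compounds shown here, compound 4 gives only a limit, as do compounds 1, 2 and 3, and no step among them can be read. The compounds shown leave open whether any chain on the shared core, with or without an amine, gives a readable value in this assay at all.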